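A larger group on the oxygen of compound 1

This account rests on a few compounds, and the source may have more. Where it says the series, first, only, none or still open, it means among the compounds named here.

- compound 1 (`COc1ccc(N(C)c2ccnc(Cl)n2)cc1O`) gives 422 nM
- compound 2 (`COc1ccc(N(C)c2ccnc(Cl)n2)cc1OCCCCBr`) gives 1140 nM
- compound 3 (`COc1ccc(N(C)c2ccnc(Cl)n2)cc1OCC[Se]C#N`) gives 1220 nM

In a functional assay on HCT-116 cells (Homo sapiens) for antiproliferative activity, read by MTT assay, with a stated time of 48 h (on this read-out higher numbers stand for weaker inhibition and lower numbers for stronger inhibition), compound 1 has the lowest number of the three (422 nM) and so shows the strongest inhibition among them. Compound 4 (`COc1ccc(N(C)c2ccnc(Cl)n2)cc1OCCCCC[Se]C#N`) has not yet been measured. It differs from compound 1 in one place (a group of 8 heavy atoms (6 carbon, 1 nitrogen, 1 selenium; no ring) in place of a hydrogen atom, on an oxygen on an aromatic ring). Like the group in compound 3, the entering group holds selenium and nitrogen and has no ring.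

Among the compounds with values here, two measured steps bear most directly on this change, since each replaces the same hydrogen on that oxygen. Both gave a modest rise beyond the scatter (a 2.7-fold higher number from compound 1 to compound 2 (0.43 log units; beyond the scatter); a 2.9-fold higher number from compound 1 to compound 3 (0.46 log units; beyond the scatter)). The two substituted compounds do not separate from each other (a 1.1-fold higher number from compound 2 to compound 3 (0.03 log units; within the scatter)), a step within the scatter. No measurement shows how the number responds to a group of the size found in compound 4, so the range must stay wide. A modest rise of similar size is therefore expected, not a large one. The expected step is a 2.8-fold higher number from compound 1 to compound 4 (0.45 log units; beyond the scatter) in the direction of weaker inhibition. Compound 4 is estimated at 1200 nM with an expected range of 500 nM to 3000 nM around it.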

Compound 4, half-maximal inhibitory concentration: > 10000 nM
Compound 4: no number, only a limit (the forecaster's own chance of this, stated with the estimate: 3%); middle value at least 8.3-fold (0.92 log units) away from the limit.
By their numbers in this assay, from the lowest: compound 1; then compounds 2 and 3 (each within the scatter of the next). At a limit, above all of these: compound 4.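

In this assay, compound 4 gives no number, only a limit of the assay: the limit of > 10000 nM in this assay, at which 1 of the 4 values shown sits. Earlier replacements of the hydrogen on this oxygen had produced only modest rises, but this one gives an at least 23-fold higher number from compound 1 to compound 4 (1.37 log units; beyond the scatter), so the number at this position does not respond alike to every group without a ring. The selenium-bearing group of compound 3 offers no safe guide to this one, with an at least 8.1-fold higher number from compound 3 to compound 4 (0.91 log units; beyond the scatter), and although compounds 2 and 3 lay within the scatter of each other, the comparison with the bromine-ended chain gives an at least 8.7-fold higher number from compound 2 to compound 4 (0.94 log units; beyond the scatter).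

The compounds shown leave open whether the loss follows from chain length alone or needs the selenium-bearing end, and a longer chain ending in bromine, set against compound 4, would separate the two. They also leave open how the number moves with chain length between compounds 3 and 4, and whether a longer chain ending in an amine or a carboxylic acid would behave in the same way.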